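The source may hold more compounds than are shown below. What is called first, only, known or untested is meant among the compounds shown, and "the series" means these compounds.

Of the compounds shown here, three sharing one core have been measured in an ADME assay on microsomes from liver (Mus musculus) for metabolic stability, with a stated time of 30 min; on this read-out lower numbers stand for a less stable compound and higher numbers for a more stable compound. Compound 1 `CCCCOC(=O)Cc1c(C(C)C)nc(CCCC)n(Cc2ccc(-c3ccccc3-c3noc(=O)[nH]3)cc2)c1=O` gives 21.6%, compound 2 `CCCCc1nc(C(C)C)c(CC(=O)OCC(C)C)c(=O)n1Cc1ccc(-c2ccccc2-c2noc(=O)[nH]2)cc1` gives 13.7%, and compound 3 `CCCCc1nc(C(C)C)c(CC(=O)OC2CCCCC2)c(=O)n1Cc1ccc(-c2ccccc2-c2noc(=O)[nH]2)cc1` gives 14.6%, the middle of the three numbers, all within the scatter of one another: its nearest neighbour is compound 2 (a number 0.9 percentage points higher from compound 2 to compound 3 (within the scatter)) and its furthest compound 1 (a number 7 percentage points lower from compound 1 to compound 3 (within the scatter)). Compound 4 `CC#CCOC(=O)Cc1c(C(C)C)nc(CCCC)n(Cc2ccc(-c3ccccc3-c3noc(=O)[nH]3)cc2)c1=O` differs from compound 3 in one place: but-2-yn-1-yl in place of cyclohexyl on an oxygen next to a carbonyl group. For the measured compounds named here, no measured step covers a but-2-yn-1-yl group, but the three swaps on that oxygen, including a number 7.9 percentage points lower from compound 1 to compound 2 (within the scatter), all stayed within the scatter, so no step beyond it is expected in this assay. The step is therefore expected to be a number 1.4 percentage points higher from compound 3 to compound 4 (within the scatter). Compound 4 is estimated at 16%, with a range from 6% to 30%.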

Compound 4, percent of the compound remaining: 16.4%
Compound 4: the middle estimate sits 0.4 percentage points below what was measured; low and high end bracket the measured number.
By their numbers in this assay, from the lowest: compounds 2, 3, 4 and 1 (each within the scatter of the next).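

In this assay, for the compounds shown here, but-2-yn-1-yl, the first group with a triple bond on this oxygen next to a carbonyl group, stays in line with all three earlier groups (a number 1.8 percentage points higher from compound 3 to compound 4 (within the scatter); a number 2.7 percentage points higher from compound 2 to compound 4 (within the scatter); a number 5.2 percentage points lower from compound 1 to compound 4 (within the scatter)). Butyl, isobutyl, cyclohexyl and but-2-yn-1-yl thus form a set in which no swap at this position leaves the scatter. No evidence is available that bears on this result. As far as these compounds go, whether a chain ending in an amine or a hydroxyl group on this oxygen would step beyond the scatter stays open. So does whether changes elsewhere on the shared core would move these numbers.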